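Step from a fluoropyridinyl to an aminophenyl substituent

The source may report more compounds than this note shows. Statements on the series, on what has been measured and on what is new or still open speak of the compounds shown alone.

Measured compounds:
compound 1, `COC(=O)c1sc2cc(-c3ccoc3)cnc2c1N` — in a functional assay on MCF7 cells (Homo sapiens) for inhibition, read by sulforhodamine B assay, with a stated time of 48 h (on this read-out higher numbers stand for weaker inhibition of growth and lower numbers for stronger inhibition of growth), compound 1 gives > 120000 nM, which is a limit of the assay rather than a number.
compound 2, `COC(=O)c1sc2cc(-c3ccc(F)nc3)cnc2c1N` — in this assay compound 2 gives "not determined" (no result reported).

So compound 2 stands without a number in this assay; the only value shown beside it is the limit of compound 1, described as the limit of > 120000 nM in this assay, at which 1 of the 2 values shown sits. Compound 3 is `COC(=O)c1sc2cc(-c3ccccc3N)cnc2c1N`. It differs from compound 2 by 2-aminophenyl in place of 6-fluoropyridin-3-yl on an aromatic carbon. Going by the values given here, with no step between measured compounds available, no direction can be read for this change; the one value that exists is a limit, so the expectation is that compound 3 will also sit at weak inhibition, possibly again only as a limit. The estimate for compound 3 in this assay is 80000 nM, expected to fall between 15000 nM and 120000 nM.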

Compound 3, concentration for 50% growth inhibition: 4200 nM
Compound 3: the middle estimate sits 19-fold (1.28 log units) above what was measured, and the stated range ends above it.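

In this assay, going by these compounds alone, this position now yields a real number for the first time: compound 3 gives 4200 nM. Exchanging furan-3-yl for 2-aminophenyl on this aromatic carbon produces an at least 28-fold lower number from compound 1 to compound 3 (1.45 log units; beyond the scatter), which shows that the substituent here can shift growth inhibition well beyond the usual scatter. Compound 1 itself remains a limit of the assay and not a number: the limit of > 120000 nM in this assay, at which 1 of the 3 values shown sits.

The step from compound 2 to compound 3 cannot be read, as compound 2 has no result, so the change from 6-fluoropyridin-3-yl remains without a measured size. The step from compound 1 changes the ring and adds the amine together, which leaves open whether a plain phenyl would retain this inhibition, or whether a hydroxyl could stand in place of the amine.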